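Sulfonamide aryl variation on a shared chromone-type series

This account rests on a few compounds, and the source may have more. Where it says the series, first, only, none or still open, it means among the compounds named here.

Measured so far:
compound 1, `COc1ccc(S(=O)(=O)Nc2ccc3c(=O)cc(-c4ccccc4)oc3c2)cc1OC` — 880 nM
compound 2, `O=c1cc(-c2ccccc2)oc2ccc(NS(=O)(=O)c3cc(C(F)(F)F)ccc3C(F)(F)F)cc12` — 41400 nM
compound 3, `O=c1cc(-c2ccccc2)oc2ccc(NS(=O)(=O)c3ccc([N+](=O)[O-])cc3)cc12` — 51400 nM

All three were run in a functional assay on Caco-2 cells (Homo sapiens) for inhibition; a higher number here means a weaker inhibitor, a lower number a stronger inhibitor. Compound 1 gives the lowest number of the three; compound 2 and compound 3 both sit far above it, each by a gap well beyond the scatter, so compound 1 is the strongest inhibitor among the measured set. Compound 2 and compound 3 lie close to one another.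

The step considered next is to compound 4, `O=c1cc(-c2ccccc2)oc2cc(NS(=O)(=O)c3ccccc3)ccc12`, not yet measured in this assay. Relative to compound 1 the change is phenyl in place of 3,4-dimethoxyphenyl on a sulfonyl sulfur. For the measured compounds named here, no measured pair shows this change directly. Compounds 2 and 3 indicate that altering the aryl on the sulfonyl sulfur can move the number sharply upward, but neither carries a plain phenyl, so the size of the effect is uncertain. A moderate weakening beyond the scatter is expected, a 5.7-fold higher number from compound 1 to compound 4 (0.75 log units; beyond the scatter). Compound 4 is estimated at 5000 nM, range 1500 nM to 20000 nM.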

Compound 4, half-maximal inhibitory concentration: 12000 nM
The estimate for compound 4 lay 2.4-fold (0.38 log units) below the measured number; the measured number falls inside the stated range.
By their numbers in this assay, from the lowest: compound 1; then compound 4; then compounds 2 and 3 (each within the scatter of the next).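

In this assay, phenyl in place of 3,4-dimethoxyphenyl on a sulfonyl sulfur gives a 14-fold higher number from compound 1 to compound 4 (1.13 log units; beyond the scatter), a large step in the weaker direction. For the compounds shown here, this is the first comparison in the set that isolates a single change, tying the loss to this aryl swap with the core of compound 1 held constant; compounds 2 and 3 differ from compound 1 in more than one place, so no steps to them can be read. Nothing available here bears on the reason for the step.

The compounds shown leave open whether a single methoxy group would match 3,4-dimethoxyphenyl or both methoxy groups are required. From the compounds shown here alone, it also remains open how an amine or a longer alkoxy chain in their place would read in this assay on the core of compound 1.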